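This account rests on a few compounds, and the source may have more. Where it says the series, first, only, none or still open, it means among the compounds named here.

The measured compounds in this set:
compound 1, `Nc1nc(-c2ccccc2)cn1/N=C/c1cc2ccccc2nc1Cl`, 49000 nM
compound 2, `Cc1ccc2nc(Cl)c(/C=N/n3cc(-c4ccccc4)nc3N)cc2c1`, 48100 nM
compound 3, `Nc1nc(-c2ccc3ccccc3c2)cn1/N=C/c1cc2ccccc2nc1Cl`, a limit of the assay, > 50000 nM

In a functional assay on MDA-MB-231 cells (Homo sapiens) for cytotoxicity, read by MTT assay, with a stated time of 48 h (on this read-out lower numbers stand for stronger inhibition and higher numbers for weaker inhibition), compound 1 gives 49000 nM. Compound 2 gives 48100 nM in this assay. For compound 3 this assay reports only a limit, > 50000 nM, which is not a number. Among the two numbers, compound 2 sits lowest, with compound 1 nearest: a 1.0-fold lower number from compound 1 to compound 2 (0.01 log units; within the scatter), so the two cannot be told apart.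

Compound 4, `Cc1ccc2nc(Cl)c(/C=N/n3cc(-c4cccc5ccccc45)nc3N)cc2c1`, has not been measured. It differs from compound 2 in one place: naphthalen-1-yl in place of phenyl on an aromatic carbon. For the measured compounds named here, no measured step covers this exchange. Going by the values given here, the only measured step, from compound 1 to compound 2, concerns a methyl group elsewhere and lies within the scatter. Compound 3 differs from compound 1 in the group on the five-membered ring, and for compound 3 the assay records only (the limit of > 50000 nM in this assay, at which 1 of the 3 values shown sits). On this slender basis the larger group is not expected to bring a gain, and the chance that the assay again reports only a limit is considerable. For compound 4 the expected step is a 1.2-fold higher number from compound 2 to compound 4 (0.10 log units; within the scatter). Compound 4 is therefore estimated at 60000 nM, within a range from 30000 nM to 150000 nM.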

Compound 4, half-maximal inhibitory concentration: > 50000 nM
Compound 4: a limit, no number; the forecaster's own chance of this, stated with the estimate: 50%; the middle value is on the limit's open side.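

In this assay compound 4 is reported only as a limit, > 50000 nM, and not as a number. Going by these compounds, the step reads an at least 1.0-fold higher number from compound 2 to compound 4 (0.01 log units; that floor lies within the scatter), so exchanging phenyl for naphthalen-1-yl on this carbon of the five-membered ring brings no measurable gain, while the true size of the step stays unknown. Until now, a larger group at this carbon had been seen only without the methyl group on the core, but the two compounds with a two-ring aromatic group here, compound 3 and compound 4, now end at the same limit with and without that methyl group: the limit of > 50000 nM in this assay, at which 2 of the 4 values shown sit.

The compounds shown leave open whether a different kind of group at this carbon, such as phenyl carrying an amine or a carboxylic acid, or a plain methyl group in place of phenyl, would give a clearly lower number than compound 2 at 48100 nM. They also leave open what the methyl group on the core would do in a compound whose number lies well clear of the limit.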